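The compounds below may be only part of what the source reports. "The series", "measured", "known", "first", "only" and "open" are said of these compounds alone.

Within the data shown here, in a functional assay on HGC-27 cells (Homo sapiens) for cytotoxicity, read by MTT assay, with a stated time of 72 h (on this read-out higher numbers stand for weaker inhibition and lower numbers for stronger inhibition), compound 1 `CCCCCCNc1nc(SCc2ccc(C(F)(F)F)cc2)nc2ccccc12` gives 23900 nM; it is one of only two numbers so far, and the other, compound 2 `FC(F)(F)c1ccc(CSc2nc(Nc3cccc(Cl)c3)c3ccccc3n2)cc1` with 19900 nM, lies within the scatter of it, as the step of a 1.2-fold lower number from compound 1 to compound 2 (0.08 log units; within the scatter) shows. Compound 3 `FC(F)(F)c1ccc(CSc2nc(Nc3cccc(Br)c3)c3ccccc3n2)cc1` differs from compound 1 by 3-bromophenyl in place of hexyl on a nitrogen on an aromatic ring. Among the measured compounds shown here, the only step that bears on this, the 3-chlorophenyl replacing hexyl, stayed within the scatter, so no step beyond the scatter is expected here either; the expected step is a 1.2-fold lower number from compound 1 to compound 3 (0.08 log units; within the scatter). Compound 3 is therefore estimated at 20000 nM, between 10000 nM and 40000 nM.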

Compound 3, half-maximal inhibitory concentration: 18300 nM
The estimate for compound 3 lay 1.1-fold (0.04 log units) above the measured number, within the range that was stated.
By their numbers in this assay, from the lowest: compounds 3, 2 and 1 (each within the scatter of the next).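

With a 1.3-fold lower number from compound 1 to compound 3 (0.12 log units; within the scatter) the 3-bromophenyl group joins 3-chlorophenyl as a second ring-bearing replacement for hexyl on this nitrogen that stays within the scatter in this assay. Among these compounds, the halogen itself is now compared directly for the first time, and a 1.1-fold lower number from compound 2 to compound 3 (0.04 log units; within the scatter) shows that bromo in place of chloro on an aromatic carbon also stays within the scatter. No measured evidence bears on why these numbers lie so close together. The compounds shown leave open whether an amine or a carboxylic acid on the phenyl ring, or a longer chain in place of hexyl, would give a step beyond the scatter.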